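The compounds below may be only part of what the source reports. "The series", "measured", "known", "first", "only" and "open" are said of these compounds alone.

Working notes on the quaternary ammonium series.

All four compounds share one core; compound 1 `Cc1cc(OCCCCCCC[N+]2(C)CCCC2)cc(-n2cc(C(=O)Nc3cc(F)cc(F)c3)c(=O)c3ccc(N(C)C)nc32)c1` and compound 2 `Cc1ccc(-n2cc(C(=O)Nc3cc(F)cc(F)c3)c(=O)c3ccc(N(C)C)nc32)cc1OCCCCCCC[N+]1(C)CCCC1` are built from the same atoms joined differently, and the difference between the two cores is not broken down here. Compound 3 `Cc1cc(OCCCCCCC[N+]2(C)CCCCC2)cc(-n2cc(C(=O)Nc3cc(F)cc(F)c3)c(=O)c3ccc(N(C)C)nc32)c1` arises from compound 1 by the change a group of 7 heavy atoms (6 carbon, 1 nitrogen; one six-membered non-aromatic ring with 1 hetero atom) in place of a group of 6 heavy atoms (5 carbon, 1 nitrogen; one five-membered non-aromatic ring with 1 hetero atom), on a saturated chain carbon, seven bonds along the chain from an oxygen on an aromatic ring and compound 4 `Cc1ccc(-n2cc(C(=O)Nc3cc(F)cc(F)c3)c(=O)c3ccc(N(C)C)nc32)cc1OCCCCCCC[N+]1(C)CCCCC1` arises from compound 2 by the change (a group of 7 heavy atoms (6 carbon, 1 nitrogen; one six-membered non-aromatic ring with 1 hetero atom) in place of a group of 6 heavy atoms (5 carbon, 1 nitrogen; one five-membered non-aromatic ring with 1 hetero atom), on a saturated chain carbon, seven bonds along the chain from an oxygen on an aromatic ring). The two place descriptions read the same, so the change in compound 4 is the same change as in compound 3.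

In an assay on LX2 cells for inhibition of COL1A1 promoter (Homo sapiens), read by a luciferase reporter, with a stated time of 24 h, tested at 20 uM (a higher number here means a stronger effect of the compound at the concentration tested, a lower number a weaker effect), compound 1 gives 4.32%. In this assay compound 2 gives 12.7%, a number within the scatter of compound 1. In this assay, among the measured compounds shown here, compound 3 gives 46.8%, and the step of a number 42.5 percentage points higher from compound 1 to compound 3 (beyond the scatter) is the only measured example of this ring change.

For the measured compounds named here, for compound 4 a step of a number 32.3 percentage points higher from compound 2 to compound 4 (beyond the scatter) in this assay is expected, resting on the one measured step of a number 42.5 percentage points higher from compound 1 to compound 3 (beyond the scatter) and on compound 2 giving 12.7%; a single precedent leaves the size uncertain. Compound 4 is estimated at 45% in this assay, between 20% and 70%.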

Compound 4, a percentage reported as inhibition, at one concentration (the size of the read-out at that concentration, not a potency): 23.4%
Beside the measured number, compound 4's estimate is 21.6 percentage points above it, and the stated range covers the measured number.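

In this assay the six-membered ring group in place of the five-membered ring group, at the same place on the chain, gives on the core of compound 2 a step of a number 10.7 percentage points higher from compound 2 to compound 4 (beyond the scatter). Set beside the step on the core of compound 1, the direction carries over but the size does not: the same change on two cores in this assay, a number 42.5 percentage points higher (beyond the scatter) from compound 1 to compound 3 and a number 10.7 percentage points higher (beyond the scatter) from compound 2 to compound 4, 31.8 percentage points apart, beyond the scatter of two such steps

These two pairs show that the ring change raises the inhibition read at the one tested concentration on both cores, and that a step measured on one core is a poor guide to the size of the step on the other; they do not show why the two sizes differ, what happens at any other concentration, or how the change would behave on any further core.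

Still open, as far as these compounds go, is whether a seven-membered azepanium ring, a morpholinium ring or an open-chain trimethylammonium group at the chain end would extend this trend on either core. Also open, from the compounds shown here alone, is how a shorter or longer chain, or an uncharged tertiary amine at the chain end, would alter the step.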